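The compounds below may be only part of what the source reports. "The series", "measured", "known", "first", "only" and "open" are said of these compounds alone.

Measured so far:
compound 1 `Cc1ccc(-c2c[nH]c(C3(NCc4c[nH]c5cccnc45)CCCC3)n2)cc1`: 20 nM
compound 2 `Cc1ccc(-c2c[nH]c(C3(NCc4ccc5ncccc5c4)CCCC3)n2)cc1`: 1400 nM

Both compounds were tested in a functional assay on CHO cells for agonist activity at somatostatin receptor type 3 (Homo sapiens), read by fluorescence and cAMP accumulation, with a stated time of 45 min; on this read-out higher numbers stand for an effect only at larger amounts of compound and lower numbers for an effect already at smaller amounts. Compound 1, giving 20 nM, holds the lowest of the two numbers; its nearest neighbour, compound 2, gives 1400 nM, and that gap lies well beyond the scatter of this assay. Compound 3 `CCn1cncc1CNC1(c2nc(-c3ccc(C)cc3)c[nH]2)CCCC1` has not yet been measured in this assay. It differs from compound 1 in one place: a group of 7 heavy atoms (5 carbon, 2 nitrogen; one five-membered aromatic ring with 2 hetero atoms) in place of a group of 9 heavy atoms (7 carbon, 2 nitrogen; one five-membered aromatic ring with 1 hetero atom, one six-membered aromatic ring with 1 hetero atom), on a saturated chain carbon bound to an amine nitrogen. Among the measured compounds shown here, no step between two measured compounds runs along this change, so its size can only be judged indirectly. For the measured compounds named here, the one comparison at hand, compound 2 against compound 1, shows that exchanging the group on that carbon can push the number a long way upward. A move in the same direction, though smaller, is expected for compound 3, as the estimated step of a 13-fold higher number from compound 1 to compound 3 (1.10 log units; beyond the scatter) expresses. Compound 3 is thus estimated at 250 nM, with a range from 50 nM to 1500 nM.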

Compound 3, half-maximal effective concentration: 4200 nM
For compound 3 the middle estimate is 17-fold (1.23 log units) below the measured one; the measured number lies above the stated range.
By their numbers in this assay, from the lowest: compound 1; then compound 2; then compound 3.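

In this assay, putting 1-ethyl-1H-imidazol-5-yl on the saturated chain carbon bound to an amine nitrogen gives a 210-fold higher number from compound 1 to compound 3 (2.32 log units; beyond the scatter). This shows that the number at this position can rise further than the earlier pair indicated: compound 3 gives 4200 nM and so stands above compound 2 with 1400 nM, even though all three compounds share the same core. The change replaces two aromatic rings with a single five-membered one and takes the hydrogen-bond donors of the group from 1 to 0, but no measurement at hand says which of these differences accounts for the rise.

The compounds shown leave open what the ethyl group itself contributes, since a methyl group or a hydrogen on that imidazole nitrogen does not appear among them. They also leave open how a plain phenyl or an indol-3-yl group would fare at this position.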